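Furan for thiophene on two naphthoquinone ether positions

The source may report more compounds than this note shows. Statements on the series, on what has been measured and on what is new or still open speak of the compounds shown alone.

Three ether-substituted quinones have been measured in a functional assay on HeLa cells (Homo sapiens) for cytotoxicity; on this read-out lower numbers stand for stronger inhibition and higher numbers for weaker inhibition. Compound 1 `O=C1C=CC(=O)c2c(Oc3ccco3)cccc21` gives 12500 nM. Compound 2 `O=C1C=CC(=O)c2c(Oc3cccs3)cccc21` gives 5210 nM, and compound 3 `O=C1C=C(Oc2cccs2)C(=O)c2ccccc21` gives 35300 nM, the highest of the three numbers; its steps to compound 1 and to compound 2 are both beyond the scatter.

Compounds 2 and 1 differ in one place, (furan-2-yl in place of thiophen-2-yl on an oxygen on an aromatic ring), and this step reads a 2.4-fold higher number from compound 2 to compound 1 (0.38 log units; beyond the scatter). Compounds 2 and 3 carry the same atoms joined differently; the difference between the two cores is not broken down here.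

Compound 4 `O=C1C=C(Oc2ccco2)C(=O)c2ccccc21` has not been measured. It differs from compound 3 by furan-2-yl in place of thiophen-2-yl on an oxygen on an unsaturated carbon. The place is not the same as in the earlier pair: there the oxygen sits on an aromatic ring whose other neighbour is an aromatic carbon, here on an unsaturated carbon whose other neighbour is a double-bonded ring carbon, so this is the same kind of change rather than the same change.

Among the measured compounds shown here, for compound 4 a step of about a 2.1-fold higher number from compound 3 to compound 4 (0.33 log units; beyond the scatter) in this assay is expected, resting on the single earlier instance a 2.4-fold higher number from compound 2 to compound 1 (0.38 log units; beyond the scatter) and allowing for the different surroundings, which leave the transfer uncertain. On that basis compound 4 is estimated at 75000 nM, with a plausible range from 30000 nM to 200000 nM; a number this high may also come back only as a limit.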

Compound 4, half-maximal inhibitory concentration: 37000 nM
Compound 4: middle estimate off by 2.0-fold (0.31 log units), on the high side; the measured number falls inside the stated range.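

In this assay, furan-2-yl in place of thiophen-2-yl on an oxygen on an unsaturated carbon reads a 1.0-fold higher number from compound 3 to compound 4 (0.02 log units; within the scatter), so the two groups cannot be told apart on this core. Set beside the earlier step on the other core, the two readings of the change do not separate: the same change on two cores in this assay, a 2.4-fold higher number (0.38 log units; beyond the scatter) from compound 2 to compound 1 and a 1.0-fold higher number (0.02 log units; within the scatter) from compound 3 to compound 4, 2.3-fold (0.36 log units) apart, within the scatter of two such steps. The result is therefore compatible with one modest step shared by both cores, but it does not show that the change carries over at the same size, and one step beyond the scatter with one within it establishes neither a common size nor a dependence on the core.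

The compounds shown hold only two aromatic ether groups, furan-2-yl and thiophen-2-yl, so the effect of a phenyl ring or a longer alkyl chain on the same oxygen on either core remains open. Also open, from the compounds shown here alone, is how an amine or a carboxylic acid carried on the outer ring would read in this assay, and whether any such group would behave alike on both cores.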